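Phenyl for 1-(chloromethyl)-1-methylethyl on the shared core

This account rests on a few compounds, and the source may have more. Where it says the series, first, only, none or still open, it means among the compounds named here.

In a functional assay on MV4-11 cells (Homo sapiens) for antiproliferative activity, read by luminescence, with a stated time of 72 h (on this read-out lower numbers stand for stronger inhibition and higher numbers for weaker inhibition), compound 1 `CC(C)(C)OC(=O)Oc1ccc(Cn2ccnc2)c2cccnc12` gives 11500 nM, and compound 2 `CC(C)(CCl)C(=O)Oc1ccc(Cn2ccnc2)c2cccnc12` gives 8900 nM. Among the compounds with values here, the two numbers cannot be told apart, since the only measured step is a 1.3-fold lower number from compound 1 to compound 2 (0.11 log units; within the scatter). Compound 2 therefore stands level with compound 1, and no trend can be read from this pair.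

Compound 3 `O=C(Oc1ccc(Cn2ccnc2)c2cccnc12)c1ccccc1` has not yet been measured. Its structure departs from that of compound 2 in one place: phenyl in place of 1-(chloromethyl)-1-methylethyl on a carbonyl carbon. In words, this is phenyl in place of 1-(chloromethyl)-1-methylethyl on a carbonyl carbon. Within the data shown here, the one measured change at this place, a 1.3-fold lower number from compound 1 to compound 2 (0.11 log units; within the scatter), is the sole guide, and it involved no ring on either side. The data therefore show nothing about what a phenyl does here, and they give no reason to expect a direction.

The estimated change is a 1.1-fold lower number from compound 2 to compound 3 (0.05 log units; within the scatter), which is expected to stay within the scatter. For compound 3 the expected value in this assay is 8000 nM, with an estimated range of 3000 nM to 20000 nM.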

Compound 3, half-maximal inhibitory concentration: 9000 nM
Compound 3: middle estimate off by 1.1-fold (0.05 log units), on the low side, within the range that was stated.
By their numbers in this assay, from the lowest: compounds 2, 3 and 1 (each within the scatter of the next).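

In this assay, within the data shown here, the step of a 1.0-fold higher number from compound 2 to compound 3 (0.00 log units; within the scatter) is the first reading of an aromatic ring on this carbonyl carbon, and phenyl cannot be told apart from the open, chlorine-bearing 1-(chloromethyl)-1-methylethyl group. The second step, a 1.3-fold lower number from compound 1 to compound 3 (0.11 log units; within the scatter), places phenyl level with tert-butoxy as well, so three quite different groups at this place now give values within the scatter of one another, and none of these changes has moved the number measurably. Nothing available bears on why these values sit so close together.

The compounds shown leave open whether any group on this carbonyl carbon can move the number beyond the scatter, since all three of these groups carry no hydrogen-bond donors or acceptors of their own and no net charge. An amine or a carboxylic acid on the phenyl ring, or a longer chain in its place, would test whether this flat reading holds beyond these three compounds.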